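The source may report more compounds than this note shows. Statements on the series, on what has been measured and on what is new or still open speak of the compounds shown alone.

Measured so far:
Compound 1, `Nc1nc(Cl)c2ncn(Cc3ccc(CCl)cc3)c2n1`: 2240 nM
Compound 2, `ClCc1cccc(Cn2cnc3c(Cl)ncnc32)c1`: 1820 nM

Both compounds were tested in a functional assay on UACC-62 cells (Homo sapiens) for cytotoxicity, read by sulforhodamine B assay, with a stated time of 48 h; a lower number here means a stronger inhibitor of growth, a higher number a weaker inhibitor of growth. Compound 2 gives 1820 nM in this assay, and compound 1 gives 2240 nM; the two numbers lie within the usual scatter of each other, so nothing separates them. Within the data shown here, compound 1 and compound 2 differ in more than one place, so no single step links them, and the two values together offer no direction for what a change on the fused core might do.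

Compound 3, `ClCc1cccc(Cn2cnc3c(Cl)nc(Cl)nc32)c1`, has not yet been measured. It follows from compound 2 by one change: chloro in place of hydrogen on an aromatic carbon. Among the measured compounds shown here, no measured pair shows a step of this kind, so the expectation rests on the two numbers alone, which sit close together. The step from compound 2 to compound 3 in this assay is expected to be small, a 1.2-fold lower number from compound 2 to compound 3 (0.08 log units; within the scatter), with no clear direction beyond the scatter. Compound 3 is therefore estimated at about 1500 nM, with a range from 500 nM to 4500 nM.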

Compound 3, concentration for 50% growth inhibition: 1860 nM
Estimate against measurement, compound 3: 1.2-fold (0.09 log units) below; low and high end bracket the measured number.
By their numbers in this assay, from the lowest: compounds 2, 3 and 1 (each within the scatter of the next).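

In this assay, among these compounds, the first step that can be read from one single change is chloro in place of hydrogen on an aromatic carbon, and it gives a 1.0-fold higher number from compound 2 to compound 3 (0.01 log units; within the scatter). At this place on the six-membered aromatic ring with 2 nitrogen, between two ring nitrogen atoms, a chlorine atom can therefore stand where a hydrogen stood without any change that this read-out can separate from the scatter, something the earlier pair, which differs in more than one place, could not show. The data hold no separate measurement that would explain this result.

As far as these compounds go, one chloro group says little about the position as a whole, so it remains open whether a methoxy group, a nitrile or a carboxylic acid at this same place would also leave the number where it is. Also open is what a single change would do at the chloro group that stands meta to the new one, since no step shown touches that group.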